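A Longer Carboxamide Chain on a Shared Core

The compounds below may be only part of what the source reports. "The series", "measured", "known", "first", "only" and "open" are said of these compounds alone.

Among the compounds with values here, compound 1 `NC(=O)CCCCN(Cc1cccc(C(N)=O)c1)C[C@H]1O[C@@H](n2cnc3c(N)ncnc32)[C@H](O)[C@@H]1O` and compound 2 `COC(=O)c1cccc(CN(CCCC(N)=O)C[C@H]2O[C@@H](n3cnc4c(N)ncnc43)[C@H](O)[C@@H]2O)c1` share one core, and no measured step between them is given. In an assay on cells for inhibition of Nicotinamide N-methyltransferase (Homo sapiens), with stated times of 10 min and 30 min (a higher number here means a weaker inhibitor, a lower number a stronger inhibitor), compound 1 gives only a limit, > 250000 nM. In this assay compound 2 likewise gives only a limit, > 250000 nM. Compound 2 therefore sits at the limit of > 250000 nM in this assay, at which 2 of the 2 values shown sit. Compound 3 `COC(=O)c1cccc(CN(CCCCC(N)=O)C[C@H]2O[C@@H](n3cnc4c(N)ncnc43)[C@H](O)[C@@H]2O)c1` differs from compound 2 by carbamoylmethyl in place of carbamoyl on a saturated chain carbon, three bonds along the chain from an amine nitrogen. Within the data shown here, since no measured step of this kind exists, no shift beyond the scatter is expected. Compound 3 is expected to remain at the limit, estimated near 300000 nM within 100000 nM to 1000000 nM. The expected step is a step that the limit leaves unreadable from compound 2 to compound 3 in this assay.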

Compound 3, half-maximal inhibitory concentration: > 250000 nM
Compound 3: no number, only a limit (the forecaster's own chance of this, stated with the estimate: 85%); the middle value is on the limit's open side.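

In this assay, within the data shown here, compound 3 gives only a limit, > 250000 nM, so no step to compound 3 from compound 1 or compound 2 can be read. The compounds shown leave open whether either structural change affects inhibition at all.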